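From Ethoxy to Trifluoromethoxy: One More Step

This account rests on a few compounds, and the source may have more. Where it says the series, first, only, none or still open, it means among the compounds named here.

Compound 1: `C=C(Br)C(=O)Nc1cccc(/C=C/C(=O)Nc2ccc(Cl)cc2)c1`, 2600 nM
Compound 2: `C=C(Br)C(=O)Nc1cccc(/C=C/C(=O)Nc2ccc(OCC)cc2)c1`, 930 nM
Compound 3: `C=C(Br)C(=O)Nc1cccc(/C=C/C(=O)Nc2ccc(OC(F)(F)F)cc2)c1`, not yet measured

Among the measured compounds shown here, in a functional assay on Jurkat cells (Homo sapiens) for inhibition, read by MTT assay, with a stated time of 72 h (on this read-out lower numbers stand for stronger inhibition and higher numbers for weaker inhibition), compound 2 has the lower of the two numbers so far, at 930 nM. Compound 3 differs from it in one group: trifluoromethyl in place of ethyl on an oxygen on an aromatic ring. Put simply, trifluoromethyl stands in place of ethyl on an oxygen on an aromatic ring, turning ethoxy into trifluoromethoxy. For the measured compounds named here, only one measured step bears on this change: a 2.8-fold lower number from compound 1 to compound 2 (0.45 log units; beyond the scatter). That step is modest but beyond the scatter, and it swapped ethoxy in for chloro, so it offers only loose guidance. The data hold no direct comparison for trifluoromethoxy. Losing the ethoxy may give back part of that step, so a modest rise is expected: a 1.8-fold higher number from compound 2 to compound 3 (0.26 log units; within the scatter). Compound 3 is estimated at 1700 nM, with an expected range from 750 nM to 3800 nM.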

Compound 3, half-maximal inhibitory concentration: 30300 nM
For compound 3 the middle estimate is 18-fold (1.25 log units) below the measured one, outside the stated range (above it).
By their numbers in this assay, from the lowest: compound 2; then compound 1; then compound 3.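

In this assay the oxygen on the aromatic ring stays in place, yet trifluoromethyl in place of ethyl brings a 33-fold higher number from compound 2 to compound 3 (1.51 log units; beyond the scatter) and makes compound 3 the weakest of the three. Trifluoromethoxy in place of chloro gives a 12-fold higher number from compound 1 to compound 3 (1.07 log units; beyond the scatter) as well, so an oxygen at this place does not by itself go with the lower numbers, and the read-out here depends strongly on which group is attached. Nothing available explains why this swap costs so much.

These compounds leave open whether methoxy or a longer chain such as propoxy would sit nearer compound 2 or compound 3. They also leave open how an amine on the same aromatic carbon would compare.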